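A Chain Hydroxy Removed: Expected Growth Inhibition

This account rests on a few compounds, and the source may have more. Where it says the series, first, only, none or still open, it means among the compounds named here.

Compound 1 `COC1=C(OC)[C@H](O)[C@H](C/C=C(\C)CC/C=C(\C)C[C@@H]2C[C@@H](C)C(=O)O2)[C@@H](C)C1=O`: 14100 nM
Compound 2 `COC1=C(OC)[C@H](O)[C@H](C/C=C(\C)CC/C=C(\C)C[C@H](O)/C=C(\C)CO)[C@@H](C)C1=O`: 12000 nM
Compound 3 `COC1=C(OC)[C@H](OC(C)=O)[C@H](C/C=C(\C)CC/C=C(\C)C[C@H](O)/C=C(\C)CO)[C@@H](C)C1=O`: 29000 nM

For the measured compounds named here, in a functional assay on A549 cells (Homo sapiens) for inhibition, read by sulforhodamine B assay, with a stated time of 48 h (a higher number here means a weaker inhibitor of growth, a lower number a stronger inhibitor of growth), compound 2 gives the lowest of the three numbers, though the step of a 1.2-fold lower number from compound 1 to compound 2 (0.07 log units; within the scatter) is within the scatter; only the step of a 2.4-fold higher number from compound 2 to compound 3 (0.38 log units; beyond the scatter) lies clearly apart. Compound 4 `COC1=C(OC)[C@H](O)[C@H](C/C=C(\C)CC/C=C(\C)C[C@H](O)C=C(C)C)[C@@H](C)C1=O` differs from compound 2 by hydrogen in place of hydroxy on a saturated chain carbon bound to a double-bonded chain carbon. Going by the values given here, no measured step touches this hydroxy; the acetyl step from compound 2 to compound 3 concerns a different oxygen, and the step from compound 1 to compound 2 changes the chain end. Among the compounds with values here, with no direct precedent, the expected step in this assay is small, in either direction or none beyond the scatter, so compound 4 is estimated at 15000 nM (6000 nM to 40000 nM), which means an expected step of a 1.3-fold higher number from compound 2 to compound 4 (0.10 log units; within the scatter).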

Compound 4, concentration for 50% growth inhibition: 9600 nM
Estimate against measurement, compound 4: 1.6-fold (0.19 log units) above; the measured number falls inside the stated range.
By their numbers in this assay, from the lowest: compounds 4, 2 and 1 (each within the scatter of the next); then compound 3.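

In this assay, for the compounds shown here, the hydroxy of the 2-(hydroxymethyl)prop-1-en-1-yl group proves dispensable for this level of growth inhibition, a point no earlier step could test: hydrogen in its place gives a 1.3-fold lower number from compound 2 to compound 4 (0.10 log units; within the scatter). The 2-methylprop-1-en-1-yl chain end also stands level with the ring-bearing chain end, with a 1.5-fold lower number from compound 1 to compound 4 (0.17 log units; within the scatter). No available evidence explains these results. From the compounds shown here alone, whether an amine, a carboxylic acid or a longer chain in place of this hydroxy would move the number beyond the scatter remains open. The compounds shown also leave open whether this tolerance extends to other cell lines.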